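Compound 4: extending the chloro tail

A few compounds are considered here, and "the series" means these few. Any claim that something is new, unique, unknown or untested is made for them only; others in the source may bear on it.

Compound 1 `O=[N+]([O-])c1cn2c(n1)OC(COCc1ccc(OC(F)(F)F)cc1)C2`: > 64000 nM (a limit)
Compound 2 `CC1(COc2ccc(Cl)cc2)Cn2cc([N+](=O)[O-])nc2O1`: > 64000 nM (a limit)
Compound 3 `O=[N+]([O-])c1cn2c(n1)OC(COc1ccc(-c3ccc(OC(F)(F)F)cc3)cn1)C2`: 47000 nM

All three compounds were tested in an ADME assay on MRC5 cells (Homo sapiens) for cytotoxicity, read by fluorescence, with a stated time of 72 h; on this read-out higher numbers stand for weaker inhibition and lower numbers for stronger inhibition. Compound 2 gives only a limit, > 64000 nM, and no number. This is the limit of > 64000 nM in this assay, at which 2 of the 3 values shown sit.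

Compound 4 `CC1(COc2ccc(-c3ccc(C(F)(F)F)cc3)cc2)Cn2cc([N+](=O)[O-])nc2O1` has 4-(trifluoromethyl)phenyl in place of chloro on an aromatic carbon, para to a large group: 4-(trifluoromethyl)phenyl in place of chloro on an aromatic carbon. Compound 3, which also has a further aromatic ring in its tail, gives a number, 47000 nM. On that basis, a small move towards stronger inhibition in this assay is expected, and the result may again be only a limit. The expected change is an at least 1.3-fold lower number from compound 2 to compound 4 (0.12 log units; that floor lies within the scatter). For compound 4 the estimated value is 48000 nM, with an expected range from 20000 nM to 64000 nM.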

Compound 4, half-maximal inhibitory concentration: > 64000 nM
Compound 4: no number, only a limit (the forecaster's own chance of this, stated with the estimate: 55%); middle value at least 1.3-fold (0.12 log units) away from the limit.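

Compound 2 and compound 4 both give only a limit, so no step can be read between them: the limit of > 64000 nM in this assay, at which 3 of the 4 values shown sit.

The compounds shown leave open whether 4-(trifluoromethyl)phenyl in place of chloro changes the cytotoxicity read-out at all.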